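Halogen swap on the benzyl of compound 2

The compounds below may be only part of what the source reports. "The series", "measured", "known", "first", "only" and "open" are said of these compounds alone.

Going by the values given here, compound 2 `O=C(C1CC1)N1CCN(Cc2nc3ccccc3n2Cc2ccccc2F)CC1` gives 40.7% in an assay on isolated protein for inhibition of aldehyde dehydrogenase 1A1 (Homo sapiens), read by spectrophotometry, tested at 10 uM (on this read-out lower numbers stand for less inhibition and higher numbers for more inhibition at the one concentration tested (going by the name of the read-out)), the second highest of the three numbers so far. Compound 1 `CC(C)=CCn1c(CN2CCN(C(=O)C3CC3)CC2)nc2ccccc21` gives 74.3%, while compound 3 `CC(C)CCn1c(OC2CCN(C(=O)c3ccco3)CC2)nc2ccccc21` gives 30.8%, which lies within the scatter of compound 2. Compound 4 `O=C(C1CC1)N1CCN(Cc2nc3ccccc3n2Cc2ccc(Cl)cc2)CC1` is compound 2 with 4-chlorophenyl in place of 2-fluorophenyl on a saturated chain carbon bound to an aromatic nitrogen. Among the compounds with values here, the only measured step at this place is a number 33.6 percentage points lower from compound 1 to compound 2 (beyond the scatter), a large drop, so the site clearly matters; no step yet exchanges one halogenated phenyl for another. With nothing to anchor the direction, a step of no more than the scatter is expected, centred near the value of compound 2: compound 4 is expected at 42%, range 18% to 66%, an expected step of a number 1.3 percentage points higher from compound 2 to compound 4 (within the scatter).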

Compound 4, a percentage reported as inhibition, at one concentration (the size of the read-out at that concentration, not a potency): 56.6%
The estimate for compound 4 lay 14.6 percentage points below the measured number; low and high end bracket the measured number.
By their numbers in this assay, from the lowest: compounds 3 and 2 (each within the scatter of the next); then compound 4; then compound 1.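

In this assay, the step of a number 15.9 percentage points higher from compound 2 to compound 4 (beyond the scatter) shows that this place on a saturated chain carbon bound to an aromatic nitrogen responds to a change between two halogenated phenyl groups, not only to replacing 2-methylprop-1-en-1-yl. That group remains ahead of 4-chlorophenyl, with a number 17.7 percentage points lower from compound 1 to compound 4 (beyond the scatter) as the step between them. Nothing measured here accounts for either step.

The 2-fluorophenyl to 4-chlorophenyl change alters both the halogen and its place on the phenyl, so the two remain unseparated. 4-Fluorophenyl and 2-chlorophenyl would pull them apart.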